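The source may report more compounds than this note shows. Statements on the series, on what has been measured and on what is new or still open speak of the compounds shown alone.

Measured compounds:
compound 1 `Cn1nnnc1SCC(=O)N/N=c1/scc(-c2ccccc2)n1-c1ccccc1`: 85.2%
compound 2 `Cc1nnc(SCC(=O)N/N=c2/scc(-c3ccc(Cl)cc3)n2-c2ccccc2)s1`: 82.8%

In a functional assay on C6 cells (Rattus norvegicus) for cytotoxicity, read by MTT assay, with a stated time of 24 h, tested at 6 ug/mL (on this read-out lower numbers stand for a stronger effect and higher numbers for a weaker effect at the one concentration tested), compound 2 gives 82.8%, the lower of the two numbers; compound 1 gives 85.2%, and the two values sit within the usual scatter of each other, so no order between them can be claimed.

Compound 3 `Cc1nnc(SCC(=O)N/N=c2/scc(-c3ccccc3)n2-c2ccccc2)s1` is not yet measured. Against compound 2 the change is hydrogen in place of chloro on an aromatic carbon: chloro leaves and hydrogen enters on an aromatic carbon of a six-membered aromatic ring of carbon only. For the measured compounds named here, no measured pair shows this change here, so no step beyond the scatter is expected in this assay in either direction. Compound 3 is estimated at 84%, between 74% and 94%, an expected step of a number 1.2 percentage points higher from compound 2 to compound 3 (within the scatter).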

Compound 3, a percentage reported as activity, at one concentration (the size of the read-out at that concentration, not a potency): 72.4%
The estimate for compound 3 lay 11.6 percentage points above the measured number, and the stated range ends above it.
By their numbers in this assay, from the lowest: compound 3; then compounds 2 and 1 (each within the scatter of the next).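

In this assay, the 4-chlorophenyl to phenyl change gives a number 10.4 percentage points lower from compound 2 to compound 3 (beyond the scatter), so chloro at this place para to a large group is not neutral, and phenyl gives the stronger effect. With phenyl fixed, 5-methyl-1,3,4-thiadiazol-2-yl in place of 1-methyl-1H-tetrazol-5-yl on the sulfur gives a number 12.8 percentage points lower from compound 1 to compound 3 (beyond the scatter), so this second position also moves the read-out. No available measurement bears on the cause of either step.

From the compounds shown here alone, whether a fluoro, methoxy or amine at that aromatic carbon would read closer to hydrogen or to chloro stays open. Also open, going by these compounds, is whether the chloro step carries over to compounds with 1-methyl-1H-tetrazol-5-yl on the sulfur.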